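Growth inhibition near the limit of the assay

A few compounds are considered here, and "the series" means these few. Any claim that something is new, unique, unknown or untested is made for them only; others in the source may bear on it.

Compound 1 `O=S(=O)(/C=C/c1ccc(F)cc1Cl)Cc1ccc(Nc2ncnc3ccccc23)cc1`: 66000 nM
Compound 2 `O=S(=O)(/C=C/c1ccc(Cl)cc1Cl)Cc1ccc(Nc2ncnc3cc(Cl)ccc23)cc1`: > 100000 nM (a limit)
Compound 3 `O=S(=O)(/C=C/c1ccc(C(F)(F)F)cc1F)Cc1ccc(Nc2ncnc3cc(Cl)ccc23)cc1`: > 100000 nM (a limit)

These values come from a functional assay on NCI/ADR-RES cells (Homo sapiens) for inhibition; on this read-out lower numbers stand for stronger inhibition of growth and higher numbers for weaker inhibition of growth. Compound 3 stands at > 100000 nM, which is a limit of the assay and not a number. That limit is shared, as the record shows in the limit of > 100000 nM in this assay, at which 2 of the 3 values shown sit.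

The next compound is compound 4 `O=S(=O)(/C=C/c1ccc(F)cc1Cl)Cc1ccc(Nc2ncnc3cc(Cl)ccc23)cc1`. Its change from compound 3 is 2-chloro-4-fluorophenyl in place of 2-fluoro-4-(trifluoromethyl)phenyl on a double-bonded chain carbon bound to a double-bonded chain carbon. For the measured compounds named here, the one measured step at this place is a step that the two limits leave unreadable from compound 2 to compound 3, and it gives no size to carry over. Going by the values given here, the only number near this change comes from compound 1, which also carries 2-chloro-4-fluorophenyl and gives 66000 nM. Compound 2 shares the core of compound 3 and also reaches only a limit, so a strong gain in this assay is not expected. What is expected, on the strength of compound 1 at 66000 nM, is a small move toward stronger inhibition at best. The expected change is an at least 1.1-fold lower number from compound 3 to compound 4 (0.07 log units; that floor lies within the scatter), and it is only loosely estimated because one bound of it is a limit. A report of a limit again would not be surprising. The estimate for compound 4 is 85000 nM, with an expected range from 45000 nM to 130000 nM.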

Compound 4, concentration for 50% growth inhibition: > 100000 nM
Compound 4: a limit, no number; the forecaster's own chance of this, stated with the estimate: 60%; middle value at least 1.1-fold (0.07 log units) from the limit.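

In this assay, the 2-chloro-4-fluorophenyl group that comes with a measured number in compound 1 gives no number in compound 4, where the rest of the molecule matches compound 2 and compound 3. For the compounds shown here, the one step that can be read is an at least 1.5-fold higher number from compound 1 to compound 4 (0.18 log units; that floor lies within the scatter), and it belongs to chloro in place of hydrogen on an aromatic carbon; its floor lies within the scatter, so it does not by itself show a real loss of growth inhibition, though the true size could be larger. The steps among compound 2, compound 3 and compound 4 cannot be read, and all three now rest at the same limit of the assay, so the change of group on the double-bonded chain carbon has brought no number on this core: the limit of > 100000 nM in this assay, at which 3 of the 4 values shown sit.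

On these data alone, how far the three groups differ from one another on this core stays open, and so does the real size of the step from the added chloro. Also open, as far as these compounds go, is whether an amine or a carboxylic acid in place of that chloro on the aromatic carbon would give a number in this assay.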